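The source may report more compounds than this note shows. Statements on the series, on what has been measured and on what is new or still open speak of the compounds shown alone.

Working notes on the series. Compound 1 `O=C(Nc1cccc(N2CCCC2=O)c1)C1CCCN(C(=O)c2cc(C(F)(F)F)cc(C(F)(F)F)c2)C1`, compound 2 `O=C(Nc1cccc(Oc2ccccc2)c1)C1CCCN(C(=O)c2cc(C(F)(F)F)cc(C(F)(F)F)c2)C1` and compound 3 `O=C(Nc1cccc(S(=O)(=O)N2CCCC2)c1)C1CCCN(C(=O)c2cc(C(F)(F)F)cc(C(F)(F)F)c2)C1` share one core and differ from one another only in the group carried on an aromatic carbon. In an ADME assay on PC-3 cells (Homo sapiens) for cytotoxicity, read by WST assay, tested at 100 uM (on this read-out lower numbers stand for less inhibition and higher numbers for more inhibition at the one concentration tested (going by the name of the read-out)), compound 1 gives 0%, compound 2 gives 1% and compound 3 gives 0%. The steps among them are small: a number 1 percentage points higher from compound 1 to compound 2 (within the scatter), no change at the digits printed from compound 1 to compound 3 (within the scatter) and a number 1 percentage points lower from compound 2 to compound 3 (within the scatter), each within the scatter. Compound 3 therefore stands level with compound 1 at the digits reported, the two together the lowest of the three numbers, and compound 2 is the furthest from it by a difference that is still within the scatter.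

Compound 4 `O=C(Nc1cccc(Cc2ccccc2)c1)C1CCCN(C(=O)c2cc(C(F)(F)F)cc(C(F)(F)F)c2)C1` has not yet been measured. The change from compound 3 is benzyl in place of (pyrrolidin-1-yl)sulfonyl on an aromatic carbon. Within the data shown here, the closest precedent is a number 1 percentage points lower from compound 2 to compound 3 (within the scatter), where phenoxy gave way to (pyrrolidin-1-yl)sulfonyl; compound 4 moves back toward a group built on a six-membered aromatic ring of carbon only. That step, like the other two, stayed within the scatter, so no step beyond the scatter is expected in this assay in either direction. Compound 4 is expected to give 2%, with a range from 0% to 15%. The estimated step of a number 2 percentage points higher from compound 3 to compound 4 (within the scatter) is expected to lie within the scatter.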

Compound 4, a percentage reported as inhibition, at one concentration (the size of the read-out at that concentration, not a potency): 0%
For compound 4 the middle estimate is 2 percentage points above the measured one; the measured number falls inside the stated range.
By their numbers in this assay, from the lowest: compounds 1, 3, 4 and 2 (each within the scatter of the next).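

At this position, on an aromatic carbon meta to a large group, this assay stays flat for a fourth group: the move from (pyrrolidin-1-yl)sulfonyl to benzyl gives no change at the digits printed from compound 3 to compound 4 (within the scatter) and shows that a group of carbon only, with 0 hydrogen-bond acceptors, reads level with one carrying 2 hydrogen-bond acceptors and a five-membered non-aromatic ring. Benzyl in place of phenoxy gives a number 1 percentage points lower from compound 2 to compound 4 (within the scatter) and benzyl in place of 2-oxopyrrolidin-1-yl gives no change at the digits printed from compound 1 to compound 4 (within the scatter) so that, among the four groups shown, none stands apart from the others, whether it holds a six-membered aromatic ring of carbon only or a five-membered non-aromatic ring. No supporting measurement bears on why the read-out stays level across these groups.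

The compounds shown leave open whether a primary amine, a carboxylic acid or a longer alkyl chain on this aromatic carbon would also stay level with these four. They also leave open whether the same flat read-out would hold if the two trifluoromethyl groups on the shared core gave way to another group, such as chlorine or methoxy.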